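Series notes: amide nitrogen substituent, compound 1 to compound 4

The compounds below may be only part of what the source reports. "The series", "measured", "known", "first", "only" and "open" are said of these compounds alone.

Measured so far:
compound 1 `Cc1ccc(OCC(=O)N(CCO)Cc2cccs2)cc1` gives 900 nM
compound 2 `CCN(Cc1cccs1)C(=O)COc1ccc(Cl)cc1` gives 39 nM
compound 3 `CCN(Cc1cccs1)C(=O)COc1ccc(CO)cc1` gives 21900 nM

All three numbers come from an assay on HEK293 cells for agonist activity at transient receptor potential cation channel subfamily M member 8 (Homo sapiens), read by fluorescence and calcium flux, with a stated time of 15 min; a lower number here means that less compound is needed, a higher number that more compound is needed for the effect. Compound 1 stands second highest of the three: compound 2 gives a much lower number and compound 3 a much higher one, both gaps beyond the scatter. Within the data shown here, the only single-point step in the set is a 560-fold higher number from compound 2 to compound 3 (2.75 log units; beyond the scatter), and it concerns the substituent on the aromatic carbon, not the amide nitrogen, so it does not bear directly on the change considered here.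

Compound 4 `Cc1ccc(OCC(=O)N(Cc2cccs2)c2ncco2)cc1` differs from compound 1 at the amide nitrogen: 1,3-oxazol-2-yl in place of 2-hydroxyethyl on an amide-type nitrogen. Compounds 1 and 2 also differ at that nitrogen, but they differ at the aromatic carbon as well, so their gap cannot be split between the two sites. Nothing measured therefore fixes the size or direction of this step. With a group at the amide nitrogen that carries no hydrogen-bond donor, as in compound 2, a somewhat lower number is expected for compound 4, a 2.3-fold lower number from compound 1 to compound 4 (0.35 log units; beyond the scatter), but with low confidence. The estimate for compound 4 in this assay is 400 nM, within a range of 80 nM to 2500 nM.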

Compound 4, half-maximal effective concentration: 0.3 nM
Compound 4: the middle estimate sits 1300-fold (3.12 log units) above what was measured, and the stated range ends above it.
By their numbers in this assay, from the lowest: compound 4; then compound 2; then compound 1; then compound 3.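

In this assay, the amide nitrogen proves to be a site of large effect in its own right: a 3000-fold lower number from compound 1 to compound 4 (3.48 log units; beyond the scatter), with 1,3-oxazol-2-yl in place of 2-hydroxyethyl and the rest of the structure unchanged. Among these compounds, the earlier compounds offered a clean step only at the aromatic carbon, a 560-fold higher number from compound 2 to compound 3 (2.75 log units; beyond the scatter), so this is the first reading at the nitrogen that is not mixed with a change elsewhere, and it shows that the group on this nitrogen can move the number by a large margin. Nothing available accounts for the size of this step.

The change replaces a saturated chain with 1 hydrogen-bond donor by a five-membered aromatic ring with 0 hydrogen-bond donors, and the compounds shown do not separate the removal of the hydroxyl from the arrival of the ring, which a 2-methoxyethyl chain or a phenyl ring on the same nitrogen would help to tell apart. Also open, as far as these compounds go, is whether 1,3-oxazol-2-yl has a similar effect when chloro or hydroxymethyl stands on the aromatic carbon.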